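This account rests on a few compounds, and the source may have more. Where it says the series, first, only, none or still open, it means among the compounds named here.

Working notes on a small set of thioureas built on the core of compound 1, `FC(F)(F)c1cccc(NC(=S)Nc2cccc(Br)c2)c1`. Within the data shown here, in an ADME assay on Vero 76 cells (Chlorocebus sabaeus) for cytotoxicity, read by crystal violet staining, with a stated time of 96 h (on this read-out higher numbers stand for lower toxicity in this test and lower numbers for higher toxicity in this test), compound 1 gives 14000 nM, the lowest of the three numbers so far. Among the measured compounds shown here, compound 2, `Fc1ccc(NC(=S)Nc2cccc(C(F)(F)F)c2)cc1Cl`, gives 20000 nM in this assay, a value within the scatter of compound 1; no step is tabulated for this pair, so the two numbers are simply set side by side. For the measured compounds named here, compound 3, `FC(F)(F)c1cccc(NC(=S)NCc2ccco2)c1`, gives 50000 nM in this assay, and the single tabulated step, a 3.6-fold higher number from compound 1 to compound 3 (0.55 log units; beyond the scatter), is the only one that clears the scatter.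

Compound 4, `Fc1cccc(NC(=S)Nc2cccc(C(F)(F)F)c2)c1`, is the next one to be read in this assay. Its difference from compound 1 is fluoro in place of bromo on an aromatic carbon. Bromo leaves and fluoro enters, on an aromatic carbon of a six-membered aromatic ring of carbon only, meta to a large group. Going by the values given here, no tabulated step covers a halogen swap at this position: the step from compound 1 to compound 3 replaces the whole 3-bromophenyl group, and the pair of compound 1 and compound 2 shows no more than two values within the scatter. For compound 4 the step of a 1.3-fold higher number from compound 1 to compound 4 (0.11 log units; within the scatter) is therefore expected to stay within the scatter. Compound 4 is estimated at 18000 nM in this assay, with a range from 8000 nM to 40000 nM.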

Compound 4, half-maximal cytotoxic concentration: 20000 nM
The estimate for compound 4 lay 1.1-fold (0.05 log units) below the measured number; the range from low to high includes it.
By their numbers in this assay, from the lowest: compounds 1, 2 and 4 (each within the scatter of the next); then compound 3.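

In this assay, the step with fluoro in place of bromo on an aromatic carbon reads a 1.4-fold higher number from compound 1 to compound 4 (0.15 log units; within the scatter), so exchanging these two halogens at this place on the six-membered aromatic ring does not move the number beyond the scatter. The step of a 2.5-fold lower number from compound 3 to compound 4 (0.40 log units; beyond the scatter), with 3-fluorophenyl in place of (furan-2-yl)methyl on an amide-type nitrogen, clears the scatter, so the separation of compound 3 now holds against two halogenated phenyl groups, not only against the 3-bromophenyl group of compound 1. No measurement is at hand that bears on the reason for either step.

The compounds shown leave open whether an amine or a carboxylic acid on the same aromatic carbon would give a step beyond the scatter, as only bromo and fluoro can be compared at this place. They also leave open whether the higher number of compound 3 goes with the furan ring itself or with the methylene link to the amide-type nitrogen, a question that a benzyl group or a directly attached furan-2-yl group at that nitrogen would address.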